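The source may report more compounds than this note shows. Statements on the series, on what has been measured and on what is new or still open speak of the compounds shown alone.

Compound 3 `COc1ccc(C(=O)NO)cc1OCc1noc(-c2ccccc2F)n1` carries a 2-fluorophenyl group on the shared core. In an assay on isolated protein for inhibition of sphingomyelin phosphodiesterase (Homo sapiens), read by fluorescence, with a stated time of 30 min (on this read-out higher numbers stand for weaker inhibition and lower numbers for stronger inhibition), compound 3 gives 21600 nM, the lowest of the two numbers shown. Its nearest neighbour is compound 2 `COc1ccc(C(=O)NO)cc1OCc1noc(-c2ccccc2)n1`, which in this assay gives 36500 nM; the step of a 1.7-fold lower number from compound 2 to compound 3 (0.23 log units; within the scatter) stays within the scatter, so the two compounds cannot be ranked. Compound 1 `COc1ccc(C(=O)NO)cc1OCc1ccc(-c2noc(-c3ccc(Br)cc3)n2)cc1` in this assay gives > 100000 nM, which is a limit and not a number, as the limit of > 100000 nM in this assay, at which 1 of the 3 values shown sits, records.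

Compound 4 `COc1ccc(C(=O)NO)cc1OCc1noc(-c2cccc(Cl)c2)n1` differs from compound 3 by 3-chlorophenyl in place of 2-fluorophenyl on an aromatic carbon. Among the compounds with values here, the only measured step that touches this ring is a 1.7-fold lower number from compound 2 to compound 3 (0.23 log units; within the scatter), and it stayed within the scatter. One halogenated phenyl exchanged for another therefore gives no ground to expect a shift in this assay beyond the scatter, in either direction.

Compound 4 is accordingly estimated at 20000 nM, with a range from 8000 nM to 50000 nM. The step of a 1.1-fold lower number from compound 3 to compound 4 (0.03 log units; within the scatter) that this estimate means is expected to lie within the scatter.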

Compound 4, half-maximal inhibitory concentration: 9220 nM
Estimate against measurement, compound 4: 2.2-fold (0.34 log units) above, and the stated range covers the measured number.
By their numbers in this assay, from the lowest: compound 4; then compounds 3 and 2 (each within the scatter of the next). At a limit, above all of these: compound 1.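

Replacing 2-fluorophenyl with 3-chlorophenyl gives a 2.3-fold lower number from compound 3 to compound 4 (0.37 log units; beyond the scatter), and chloro in place of hydrogen gives a 4.0-fold lower number from compound 2 to compound 4 (0.60 log units; beyond the scatter), so in this assay a change on this phenyl ring now moves the number beyond the scatter, though only modestly. Compound 4 differs from compound 3 in both the halogen and where it sits on the ring, so these steps cannot show which of the two matters. Nothing measured here accounts for the lower number of compound 4.

The compounds shown leave open whether the trend extends beyond halogens, since the phenyl ring carries only fluoro or chloro in this set. Going by these compounds, how a methoxy group, an amine or a carboxylic acid on this ring would read in this assay also remains open.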